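Swapping Trifluoromethyl for Methyl on a Side Chain

This account rests on a few compounds, and the source may have more. Where it says the series, first, only, none or still open, it means among the compounds named here.

Compound 1 `CCn1nc(C)c2c1CCN(C(C(=O)NC)c1ccccc1)C2CCc1cccc(C(F)(F)F)c1` holds the lower of two numbers in a functional assay on CHO cells for antagonist activity at Orexin/Hypocretin receptor type 1 (Homo sapiens), read by FLIPR and calcium flux (on this read-out higher numbers stand for weaker inhibition and lower numbers for stronger inhibition), where compound 1 gives 358 nM. Compound 2 `CCn1nc(C)c2c1CCN([C@@H](C(=O)NC)c1ccccc1)[C@H]2COc1ccc(C)cc1`, which carries a different side chain, gives 10000 nM in this assay. Compound 3 `CCn1nc(C)c2c1CCN(C(C(=O)NC)c1ccccc1)C2CCc1cccc(C)c1` differs from compound 1 only in methyl in place of trifluoromethyl on an aromatic carbon. Going by the values given here, no measured pair shows this change, so the expectation rests on compound 1 alone. The estimate is a modest weakening, a 2.2-fold higher number from compound 1 to compound 3 (0.35 log units; beyond the scatter), a step just beyond the usual scatter. Compound 3 is therefore expected to give about 800 nM, within a likely range from 250 nM to 2500 nM.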

Compound 3, half-maximal inhibitory concentration: 180 nM
The estimate for compound 3 lay 4.4-fold (0.65 log units) above the measured number; measured number outside the range, below it.
By their numbers in this assay, from the lowest: compounds 3 and 1 (each within the scatter of the next); then compound 2.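

In this assay, methyl in place of trifluoromethyl on this aromatic carbon gives a 2.0-fold lower number from compound 1 to compound 3 (0.30 log units; within the scatter), so the two groups cannot be told apart on this read-out. This position of the ring therefore takes either group without a difference beyond the scatter, at least for this pair. No measurement here offers a reason for this result. Still open, as far as these compounds go, is how a chlorine atom, a methoxy group or an amine at this same place would read, since two groups alone give no trend.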